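The compounds below may be only part of what the source reports. "The series", "measured", "known", "first", "only" and "open" are said of these compounds alone.

Working notes on the series. Two compounds have numbers in an assay on isolated protein for inhibition of thyroid hormone receptor beta (Homo sapiens), read by fluorescence, with a stated time of 30 min (on this read-out higher numbers stand for weaker inhibition and lower numbers for stronger inhibition), so far. Compound 1 `COc1cc(C(=O)N2CCCC2(C)C)cc2nc(NCc3cccc(Cl)c3)oc12` gives 47 nM in this assay. Among the compounds with values here, compound 2 `COc1cc(C(=O)N2CCC(O)C(C)C2)cc2nc(NCc3ccnc(Cl)c3)oc12` gives 6900 nM in this assay and thus stands at the highest number of the two; compound 1 sits well beyond the scatter from it, and no single-point step between the two is counted, so their two values are all that can be said of the pair.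

Compound 3 `COc1cc(C(=O)N2CCC(O)C(C)C2)cc2nc(NC3(c4cccc(Cl)c4)CCC3)oc12` has not yet been measured. It differs from compound 2 by 1-(3-chlorophenyl)cyclobutyl in place of (2-chloropyridin-4-yl)methyl on a nitrogen on an aromatic ring. The aromatic ring of carbon only that enters carries the same chlorine pattern as the ring in compound 1, while the amide part of compound 2 is kept unchanged.

An improvement is expected, meaning a step toward lower numbers from compound 2 to compound 3 of about a 23-fold lower number from compound 2 to compound 3 (1.36 log units; beyond the scatter), because compound 1 with a chlorophenyl-bearing group on the same nitrogen gives 47 nM in this assay. Within the data shown here, the four-membered ring that enters has no counterpart among the measured compounds, so the size of the step is uncertain. Compound 3 is estimated at 300 nM in this assay, within a range of 60 nM to 1500 nM.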

Compound 3, half-maximal inhibitory concentration: 8200 nM
Beside the measured number, compound 3's estimate is 27-fold (1.44 log units) below it; measured number above the stated range.
By their numbers in this assay, from the lowest: compound 1; then compounds 2 and 3 (each within the scatter of the next).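

In this assay, within the data shown here, 1-(3-chlorophenyl)cyclobutyl in place of (2-chloropyridin-4-yl)methyl on a nitrogen on an aromatic ring gives a 1.2-fold higher number from compound 2 to compound 3 (0.07 log units; within the scatter), the first step read at a single place. With the amide part held fixed, this position therefore accepts a substantial change without any shift beyond the scatter: the six-membered aromatic ring with a hetero atom gives way to one of carbon only, the hydrogen-bond acceptor count of the group falls, and a four-membered ring of carbon only enters. Nothing on hand explains why the two values stay within the scatter of each other, or separates the contributions of the ring exchange and the cyclobutyl ring, which enter together in this one step.

The amide part has no single-place step of its own, so what it contributes to the numbers cannot be read from the compounds shown. Also open, going by these compounds, is whether a cyclopropyl or cyclopentyl ring in place of the cyclobutyl, or an amine or a carboxylic acid on the phenyl ring, would move the number at this position.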